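The compounds below may be only part of what the source reports. "The series", "measured", "known", "first", "only" and "open" are said of these compounds alone.

Measured so far in a functional assay on HT-29 cells (Homo sapiens) for cytotoxicity, read by MTT assay, with a stated time of 24 h, tested at 6.4 ug/mL; on this read-out lower numbers stand for a weaker effect and higher numbers for a stronger effect at the one concentration tested:
compound 1 `Cc1ccc2oc(SCC(=O)Nc3ccc(-c4nc(-c5ccccc5)c(-c5ccccc5)n4C)cc3)nc2c1`: 25.6%
compound 2 `Cn1cnnc1SCC(=O)Nc1ccc(-c2nc(-c3ccccc3)c(-c3ccccc3)n2C)cc1`: 43.1%
compound 3 `Cn1nnnc1SCC(=O)Nc1ccc(-c2nc(-c3ccccc3)c(-c3ccccc3)n2C)cc1`: 60.6%

Compound 3 holds the highest value of the three, and both gaps lie beyond the scatter: a number 17.5 percentage points higher from compound 2 to compound 3 (beyond the scatter) and a number 35 percentage points higher from compound 1 to compound 3 (beyond the scatter). Compound 4 `Cc1nnc(SCC(=O)Nc2ccc(-c3nc(-c4ccccc4)c(-c4ccccc4)n3C)cc2)s1` has not been measured. It differs from compound 3 in one place: 5-methyl-1,3,4-thiadiazol-2-yl in place of 1-methyl-1H-tetrazol-5-yl on a sulfur.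

All three measured steps touch the same place, the aromatic ring on the sulfur, and each was beyond the scatter. The exchange of the fused ring for a five-membered ring with three hetero atoms read a number 17.5 percentage points higher from compound 1 to compound 2 (beyond the scatter); the further exchange for a five-membered ring with four hetero atoms read a number 17.5 percentage points higher from compound 2 to compound 3 (beyond the scatter). Among the measured compounds shown here, compound 4 again carries a five-membered ring with three hetero atoms, as compound 2 does, though here with one sulfur and two nitrogens rather than three nitrogens; no measured pair tests that particular exchange, so the comparison with compound 2 is the nearest guide. For compound 4 the expected step is a number 15.6 percentage points lower from compound 3 to compound 4 (beyond the scatter), a modest fall back toward the value of compound 2. Compound 4 is therefore estimated at 45%, with a range from 28% to 62%.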

Compound 4, a percentage reported as activity, at one concentration (the size of the read-out at that concentration, not a potency): 73%
Compound 4: middle estimate off by 28 percentage points, on the low side, and the stated range ends below it.
By their numbers in this assay, from the lowest: compound 1; then compound 2; then compound 3; then compound 4.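

In this assay, the step of a number 12.4 percentage points higher from compound 3 to compound 4 (beyond the scatter) shows that the read-out at this position does not simply follow the count of ring hetero atoms, as compounds 1 to 3 alone might have suggested: 5-methyl-1,3,4-thiadiazol-2-yl, with 3 hetero atoms, exceeds 1-methyl-1H-tetrazol-5-yl, with 4. Two rings with 3 hetero atoms are also far from interchangeable on this sulfur, as the step of a number 29.9 percentage points higher from compound 2 to compound 4 (beyond the scatter) separates the ring with one sulfur and two nitrogens from 4-methyl-4H-1,2,4-triazol-3-yl, with three nitrogens. The position now spans the step of a number 47.4 percentage points higher from compound 1 to compound 4 (beyond the scatter) and compound 4 is the highest of the four, but nothing available explains this order.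

Going by these compounds, what an amine or an ethyl group in place of the methyl on the 5-methyl-1,3,4-thiadiazol-2-yl ring would give remains open, as does the read-out of an unsubstituted 1,3,4-thiadiazol-2-yl ring on the same sulfur. On these data alone, each value also comes from a single concentration in one cell line, so the effect of compound 4 at other concentrations and the reach of this order beyond these cells remain unknown.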